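This account rests on a few compounds, and the source may have more. Where it says the series, first, only, none or still open, it means among the compounds named here.

Measured compounds:
Compound 1 `COc1ccc(-c2cn3ccnc3c(-c3ccc4ncn(C5CCCCC5)c4c3)n2)cc1`: -8.6%
Compound 2 `Fc1ccc(-c2cn3ccnc3c(-c3ccc4ncn(C5CCCCC5)c4c3)n2)cc1`: 33.3%
Compound 3 `COc1ccccc1-c1cn2ccnc2c(-c2ccc3ncn(C4CCCCC4)c3c2)n1`: 36.6%

In a functional assay on T47D cells (Homo sapiens) for inhibition, read by sulforhodamine B assay, with a stated time of 48 h, tested at 10 uM (on this read-out higher numbers stand for more inhibition at the one concentration tested (going by the name of the read-out) and lower numbers for less inhibition), compound 1 gives -8.6%, the lowest of the three. The change fluoro in place of methoxy on an aromatic carbon brought a number 41.9 percentage points higher from compound 1 to compound 2 (beyond the scatter). The two cores differ as 2-methoxyphenyl in place of 4-methoxyphenyl on an aromatic carbon, and that rearrangement gave a number 45.2 percentage points higher from compound 1 to compound 3 (beyond the scatter). Between compound 2 and compound 3 the step is a number 3.3 percentage points higher from compound 2 to compound 3 (within the scatter), so these two cannot be ranked.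

Compound 4 `Fc1ccccc1-c1cn2ccnc2c(-c2ccc3ncn(C4CCCCC4)c3c2)n1` has not yet been tested in this assay. It arises from compound 3 by fluoro in place of methoxy on an aromatic carbon, the same kind of change as that from compound 1 to compound 2, but not the same: there the fluoro sat para to a large group, here it sits ortho to a large group. The earlier step was large, yet it started from a low value, while compound 3 already stands higher. The expected step is therefore a number 9.4 percentage points higher from compound 3 to compound 4 (within the scatter), a gain smaller than the earlier one, resting only on a number 41.9 percentage points higher from compound 1 to compound 2 (beyond the scatter) and on the value of compound 3, 36.6%. Compound 4 is estimated at 46%, between 22% and 70%.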

Compound 4, a percentage reported as inhibition, at one concentration (the size of the read-out at that concentration, not a potency) in the T47D assay: 77.2%
The estimate for compound 4 lay 31.2 percentage points below the measured number; the measured number lies above the stated range.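

In the T47D assay compound 4 gives 77.2%, and the step is a number 40.6 percentage points higher from compound 3 to compound 4 (beyond the scatter). In the T47D assay, replacing methoxy with fluoro gave steps of matching size on the 2-substituted and 4-substituted phenyl cores, so in this pair of cases the gain carried over from one core to the other: the same change on two cores in the T47D assay, a number 41.9 percentage points higher (beyond the scatter) from compound 1 to compound 2 and a number 40.6 percentage points higher (beyond the scatter) from compound 3 to compound 4, 1.3 percentage points apart, within the scatter of two such steps

The remaining steps are also large, a number 43.9 percentage points higher from compound 2 to compound 4 (beyond the scatter) and a number 85.8 percentage points higher from compound 1 to compound 4 (beyond the scatter), which places the 2-fluorophenyl compound beyond the scatter of all three others on this read-out. Going by these compounds alone, this agreement still rests on only two pairs, each read at one concentration, so it does not show that the change would carry to a third core or to another ring position, and it gives no reason for the gain; in a physicochemical assay for lipophilicity, using the shake flask method, in phosphate buffer, measured as octanol-water partition, with a stated time of 85 min, at pH 7.4 (on this read-out higher numbers stand for higher lipophilicity and lower numbers for lower lipophilicity), compound 3 gives 1.72 and compound 4 gives 1.95, and the step is a number 0.23 log units higher from compound 3 to compound 4 (within the scatter).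

The compounds shown leave open whether a chloro or a nitrile in place of the fluoro would give a step of the same size. They also leave open what an amine or a carboxylic acid on that phenyl ring would do.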